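The source may hold more compounds than are shown below. What is called first, only, known or untested is meant among the compounds shown, and "the series" means these compounds.

Working notes on the piperidine nitrogen substituent of the shared core. Compound 1 `COC(=O)N1CCC(Oc2ncnc3c2CCN3c2ccc(S(C)(=O)=O)cc2F)CC1` carries a methoxycarbonyl on that nitrogen, compound 2 `CCCOC(=O)N1CCC(Oc2ncnc3c2CCN3c2ccc(S(C)(=O)=O)cc2F)CC1` a propoxycarbonyl and compound 3 `CCS(=O)(=O)N1CCC(Oc2ncnc3c2CCN3c2ccc(S(C)(=O)=O)cc2F)CC1` an ethylsulfonyl. In a functional assay on CHO-K1 cells with Glucose-dependent insulinotropic receptor (Homo sapiens) as the target, read by a luciferase reporter, with a stated time of 5 h (on this read-out lower numbers stand for smaller maximal responses and higher numbers for larger maximal responses), compound 1 gives 119%, the highest of the three numbers. Compound 2 gives 111%; the step of a number 8 percentage points lower from compound 1 to compound 2 (within the scatter) lies within the scatter, so compounds 1 and 2 are not distinguished by this read-out. Compound 3 gives 51%, and the steps of a number 68 percentage points lower from compound 1 to compound 3 (beyond the scatter) and a number 60 percentage points lower from compound 2 to compound 3 (beyond the scatter) are both large and beyond the scatter.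

Compound 4 `CC(C)S(=O)(=O)N1CCC(Oc2ncnc3c2CCN3c2ccc(S(C)(=O)=O)cc2F)CC1` is not yet measured. Against compound 1 the change is isopropylsulfonyl in place of methoxycarbonyl on an amine nitrogen in a ring. The measured steps that bear on it are the two exchanges of an alkoxycarbonyl for a sulfonyl on the same ring nitrogen, a number 68 percentage points lower from compound 1 to compound 3 (beyond the scatter) and a number 60 percentage points lower from compound 2 to compound 3 (beyond the scatter). Within the data shown here, the isopropylsulfonyl of compound 4 differs from the ethylsulfonyl of compound 3 only in the alkyl part, and no measured pair shows what that alone does. A large downward step in this assay is therefore expected, close to the size seen for compound 3. Compound 4 is estimated at 50%, with a range from 30% to 75%, which means an expected step of a number 69 percentage points lower from compound 1 to compound 4 (beyond the scatter).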

Compound 4, largest response reached (reported as percent of maximum), in percent of the reference or control that the assay uses: 62%
Compound 4: the middle estimate sits 12 percentage points below what was measured, within the range that was stated.
By their numbers in this assay, from the lowest: compound 3; then compound 4; then compounds 2 and 1 (each within the scatter of the next).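

The isopropylsulfonyl of compound 4 also stays far under both alkoxycarbonyl compounds in this assay, with a number 57 percentage points lower from compound 1 to compound 4 (beyond the scatter) and a number 49 percentage points lower from compound 2 to compound 4 (beyond the scatter), so the low maximal response at this ring nitrogen is not confined to the ethylsulfonyl of compound 3. The alkyl part of the sulfonyl now has a measured effect of its own: methyl in place of hydrogen on the saturated chain carbon gives a number 11 percentage points higher from compound 3 to compound 4 (beyond the scatter), a modest step. Across compounds 1 to 4, the exchange of an alkoxycarbonyl for a sulfonyl therefore outweighs this change within the sulfonyl group, and neither sulfonyl compound comes near the level of the two carbamates. Nothing available bears on the reason for these steps.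

As far as these compounds go, whether a longer chain or a cyclopropyl on the sulfonyl would extend the modest rise seen with isopropylsulfonyl remains open. Also open, from the compounds shown here alone, is whether an amide or a urea on the ring nitrogen, each keeping a carbonyl there, would fall with compounds 1 and 2 or nearer to compounds 3 and 4.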